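The source may report more compounds than this note shows. Statements on the series, on what has been measured and on what is new or still open speak of the compounds shown alone.

Working notes on the series. Four compounds share one core: compound 1 `CC(CCNC(=O)c1c(Cl)cncc1Cl)N1CCC(C(Oc2ccccn2)c2ccc(C(F)(F)F)cc2)CC1`, compound 2 `Cc1cccnc1OC(c1ccc(C(F)(F)F)cc1)C1CCN(C(C)CCNC(=O)c2c(Cl)cncc2Cl)CC1`, compound 3 `CC(CCNC(=O)c1c(Cl)cncc1Cl)N1CCC(C(Oc2ccccc2C(F)(F)F)c2ccc(C(F)(F)F)cc2)CC1` and compound 4 `CC(CCNC(=O)c1c(Cl)cncc1Cl)N1CCC(C(Oc2cccc(C#N)n2)c2ccc(C(F)(F)F)cc2)CC1`, which is not yet measured. In an ADME assay on PBMC cells (Homo sapiens) for cytotoxicity (a lower number here means that less compound is tolerated, a higher number that more compound is tolerated), compound 1 gives 34100 nM. Compound 2 gives 33000 nM in this assay. Compound 3 gives 12500 nM in this assay, the lowest of the three numbers, with the nearest neighbour compound 2 and the furthest compound 1, both beyond the scatter.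

The step to compound 4 reads (6-cyanopyridin-2-yl in place of 2-(trifluoromethyl)phenyl on an oxygen on a saturated carbon). Going by the values given here, two measured steps bear on it, since both swap the group on the same oxygen: a 2.7-fold lower number from compound 1 to compound 3 (0.44 log units; beyond the scatter) and a 2.6-fold lower number from compound 2 to compound 3 (0.42 log units; beyond the scatter). In each, a pyridin-2-yl type ether was replaced by 2-(trifluoromethyl)phenyl and the number fell modestly. Compound 4 runs that exchange the other way, putting a pyridinyl back on the oxygen, now carrying a nitrile, so the expectation is a modest rise toward the numbers of compound 1 and compound 2 rather than a further fall.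

The step expected for compound 4 is therefore a 2.1-fold higher number from compound 3 to compound 4 (0.32 log units; beyond the scatter). Compound 4 is estimated at 26000 nM in this assay, within a range from 12000 nM to 55000 nM.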

Compound 4, half-maximal cytotoxic concentration: 15700 nM
Beside the measured number, compound 4's estimate is 1.7-fold (0.22 log units) above it, within the range that was stated.
By their numbers in this assay, from the lowest: compounds 3 and 4 (each within the scatter of the next); then compounds 2 and 1 (each within the scatter of the next).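

At this position on the oxygen, a pyridinyl ring alone does not keep the number of this assay with compounds 1 and 2: 6-cyanopyridin-2-yl and 2-(trifluoromethyl)phenyl are not separated here (a 1.3-fold higher number from compound 3 to compound 4 (0.10 log units; within the scatter)). Going by these compounds alone, the earlier fall to compound 3 changed the ring and its substituent together, whereas the nitrile is now the single change from the unsubstituted pyridin-2-yl (a 2.2-fold lower number from compound 1 to compound 4 (0.34 log units; beyond the scatter)), and the exchange with 3-methylpyridin-2-yl gives a step of similar size (a 2.1-fold lower number from compound 2 to compound 4 (0.32 log units; beyond the scatter)). Substitution on the pyridinyl ring does not lower the number in every case, since compound 2 goes against that reading: its methyl in place of hydrogen stays within the scatter (a 1.0-fold lower number from compound 1 to compound 2 (0.01 log units; within the scatter)), so among these compounds the lowering goes with the nitrile and not with the methyl.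

No measurement here gives a cause for these steps. Still open, going by these compounds, is whether a methoxy, an amine or a carboxylic acid on the pyridinyl ring would stand with compound 1 or with compound 4, and where an unsubstituted phenyl on this oxygen would fall.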